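Swapping the Para Substituent on a Nitrofuran Hydrazone

A few compounds are considered here, and "the series" means these few. Any claim that something is new, unique, unknown or untested is made for them only; others in the source may bear on it.

Measured so far:
- compound 1 `CCCCNc1ccc(C(=O)N/N=C/c2ccc([N+](=O)[O-])o2)cc1`: 47000 nM
- compound 2 `CCCc1ccc(C(=O)N/N=C/c2ccc([N+](=O)[O-])o2)cc1`: 89000 nM

In an ADME assay on LL24 cells (Homo sapiens) for inhibition, read by MTT assay, with a stated time of 24 h (a higher number here means a weaker inhibitor, a lower number a stronger inhibitor), compound 1 gives the lowest of the two numbers, with compound 2 nearest at a 1.9-fold higher number from compound 1 to compound 2 (0.28 log units; within the scatter). Compound 3 `CC(C)(C)c1ccc(C(=O)N/N=C/c2ccc([N+](=O)[O-])o2)cc1` has not yet been measured; it differs from compound 1 by tert-butyl in place of butylamino on an aromatic carbon. Among the measured compounds shown here, the only step that bears on this change, from compound 1 to compound 2, swaps the same butylamino for a plain carbon chain and stays within the scatter, so no step beyond the scatter is expected here either, at most a drift toward a higher number. Compound 3 is therefore expected to give 75000 nM in this assay, within the range 30000 nM to 190000 nM, an expected 1.6-fold higher number from compound 1 to compound 3 (0.20 log units; within the scatter).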

Compound 3, half-maximal inhibitory concentration: > 200000 nM
Compound 3: only a limit was reported (the forecaster's own chance of this, stated with the estimate: 10%); at least 2.6-fold (0.42 log units) between middle value and limit.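

In this assay, compound 3 gives only a limit, not a number: the limit of > 200000 nM in this assay, at which 1 of the 3 values shown sits. Even so, this position proves sensitive to the group it carries: tert-butyl in place of butylamino gives an at least 4.2-fold higher number from compound 1 to compound 3 (0.62 log units; beyond the scatter), and tert-butyl in place of propyl gives an at least 2.2-fold higher number from compound 2 to compound 3 (0.35 log units; beyond the scatter). Among the compounds shown here, the earlier swap of butylamino for propyl stayed within the scatter, so tert-butyl is the first change here to go beyond it.

As far as these compounds go, how far compound 3 lies past its limit remains unknown. Also open, from the compounds shown here alone, is how a free amine, a methyl group or a carboxylic acid would read at this position.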